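The source may hold more compounds than are shown below. What is called first, only, known or untested is meant among the compounds shown, and "the series" means these compounds.

In an ADME assay on MT4 cells (Homo sapiens) for cytotoxicity, read by MTT assay (on this read-out lower numbers stand for higher toxicity in this test and higher numbers for lower toxicity in this test), three compounds built on one shared core have been measured. Compound 1 `CC(=O)c1ccc(NC(=O)CSc2nncnc2-c2cccc3ccccc23)c(Br)c1` gives 133000 nM, compound 2 `O=C(CSc1nncnc1-c1cccc2ccccc12)Nc1ccccc1Br` gives 87000 nM, and compound 3 `CCOC(=O)c1ccc(NC(=O)CSc2nncnc2-c2cccc3ccccc23)c(Br)c1` gives 105000 nM, so the numbers do not separate compound 3 from the other two. The step followed here leads to compound 4 `NS(=O)(=O)c1ccc(NC(=O)CSc2nncnc2-c2cccc3ccccc23)c(Br)c1`: sulfamoyl in place of ethoxycarbonyl on an aromatic carbon. In short, it places sulfamoyl in place of ethoxycarbonyl on an aromatic carbon. Within the data shown here, no measured step makes this exact exchange, and no measured compound carries sulfamoyl. The nearest evidence is a 1.2-fold higher number from compound 2 to compound 3 (0.08 log units; within the scatter), where ethoxycarbonyl replaces hydrogen on that aromatic carbon, together with a 1.5-fold lower number from compound 1 to compound 2 (0.18 log units; within the scatter) and a 1.3-fold lower number from compound 1 to compound 3 (0.10 log units; within the scatter). Among the measured compounds shown here, all three steps lie within the scatter of this assay, so the three compounds offer no precedent for a larger move, and none beyond the scatter is expected here. The expected step is a 1.1-fold lower number from compound 3 to compound 4 (0.02 log units; within the scatter). For compound 4 the estimate is 100000 nM, with an expected range from 50000 nM to 200000 nM.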

Compound 4, half-maximal cytotoxic concentration: 23000 nM
For compound 4 the middle estimate is 4.3-fold (0.64 log units) above the measured one, and the stated range ends above it.
By their numbers in this assay, from the lowest: compound 4; then compounds 2, 3 and 1 (each within the scatter of the next).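

In this assay, the aromatic carbon para to a large group and meta to a bromo group proves not to be indifferent to what it carries: sulfamoyl gives a 4.6-fold lower number from compound 3 to compound 4 (0.66 log units; beyond the scatter), a 3.8-fold lower number from compound 2 to compound 4 (0.58 log units; beyond the scatter) and a 5.8-fold lower number from compound 1 to compound 4 (0.76 log units; beyond the scatter). Hydrogen, acetyl and ethoxycarbonyl at this carbon had stayed within the scatter of one another, so compound 4 is the first to stand apart, with the lower number indicating higher toxicity in this test. Nothing available accounts for this drop.

Going by these compounds, it remains open whether the lower number is particular to sulfamoyl or also appears with other groups at this carbon, such as a carboxylic acid, an amine or methylsulfonyl. Whether the step keeps its size without the bromo group is also unresolved.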